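A few compounds are considered here, and "the series" means these few. Any claim that something is new, unique, unknown or untested is made for them only; others in the source may bear on it.

Measured so far in a functional assay on MCF7 cells (Homo sapiens) for antiproliferative activity, read by MTT assay, with a stated time of 48 h; a lower number here means a stronger inhibitor, a higher number a weaker inhibitor (two compounds)
- compound 1 `O=[N+]([O-])c1cccc(-c2nn(-c3ccccc3)cc2C(Nc2nc3ccccc3s2)c2c(O)ccc3ccccc23)c1` gives 43900 nM
- compound 2 `COc1cccc(-c2nn(-c3ccccc3)cc2C(Nc2nc3ccccc3s2)c2c(O)ccc3ccccc23)c1` gives 16900 nM

Compound 2 holds the lower of these two numbers, which makes it the stronger inhibitor of the pair. Still unmeasured is compound 3 `Cc1cccc(-c2nn(-c3ccccc3)cc2C(Nc2nc3ccccc3s2)c2c(O)ccc3ccccc23)c1` which keeps the shared core. It differs from compound 2 in one place, with methyl in place of methoxy on an aromatic carbon so that 3-methoxyphenyl becomes 3-methylphenyl.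

Among the measured compounds shown here, only one measured step bears on this position: a 2.6-fold lower number from compound 1 to compound 2 (0.41 log units; beyond the scatter) when methoxy replaced nitro on that same carbon. That step was modest. For the measured compounds named here, no measured compound carries a methyl group, so the data do not show the direction of the new change. The swap from methoxy to methyl is therefore expected to give a step no larger than that one, and possibly none beyond the usual scatter. The estimate amounts to a 1.1-fold higher number from compound 2 to compound 3 (0.05 log units; within the scatter) as the expected step. Compound 3 is expected near 19000 nM with an estimated range from 9000 nM to 38000 nM when tested in this assay conditions.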

Compound 3, half-maximal inhibitory concentration: 17300 nM
Compound 3: the middle estimate sits 1.1-fold (0.04 log units) above what was measured; the range from low to high includes it.
By their numbers in this assay, from the lowest: compounds 2 and 3 (each within the scatter of the next); then compound 1.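

Swapping methoxy for methyl on this aromatic carbon gives a 1.0-fold higher number from compound 2 to compound 3 (0.01 log units; within the scatter) in this assay and is the first change at this position that stays within the scatter, so the two groups cannot be told apart here, although methoxy carries a hydrogen-bond acceptor and methyl carries none. Methyl in place of nitro gives a 2.5-fold lower number from compound 1 to compound 3 (0.40 log units; beyond the scatter) and, like a 2.6-fold lower number from compound 1 to compound 2 (0.41 log units; beyond the scatter), lies beyond the scatter, so among these three compounds, nitro alone separates from the other two groups, with compound 1 the weakest inhibitor of the set. No measurement available here explains either the match between methoxy and methyl or the gap to nitro.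

Among the compounds shown here, these compounds cover only three groups at one carbon of this ring, and all three numbers remain in the same weak range, so it remains open whether an amine, a carboxylic acid, a hydroxyl or a chlorine there would sit with methoxy and methyl or with nitro. As far as these compounds go, whether methoxy and methyl would also match elsewhere on the ring, or on a different version of the shared core, also remains open.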